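Cytotoxicity notes on a uracil-type series, compounds 1 to 4

The source may hold more compounds than are shown below. What is called first, only, known or untested is meant among the compounds shown, and "the series" means these compounds.

Measured so far:
compound 1 `Cc1cc(C)cc(Cn2c(=O)cc(N=[N+]=[N-])n(Cc3ccccn3)c2=O)c1` — > 100000 nM
compound 2 `Cc1cc(C)cc(Cn2c(=O)cc(NC3CCCCC3)n(Cc3ccccc3)c2=O)c1` — 74000 nM
compound 3 `Cc1cc(C)cc(Cn2c(=O)cc(N=[N+]=[N-])n(CC#N)c2=O)c1` — 60000 nM

In an ADME assay on MT4 cells (Homo sapiens) for cytotoxicity, read by MTT assay, with a stated time of 4 days (on this read-out higher numbers stand for lower toxicity in this test and lower numbers for higher toxicity in this test), compound 1 gives only a limit, > 100000 nM, and no number. Compound 2 holds the highest of the two numbers measured in this assay, with 74000 nM; its nearest neighbour is compound 3, at 60000 nM, and the gap between these two is within the scatter, so no order can be read from it.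

For the measured compounds named here, the only step measured between compounds that differ in one place is the one from compound 1 to compound 3, with an at least 1.6-fold lower number from compound 1 to compound 3 (0.22 log units; that floor lies within the scatter); it concerns the group on the saturated chain carbon bound to an aromatic nitrogen, not the amine that is altered next.

Compound 4 `CNc1cc(=O)n(Cc2cc(C)cc(C)c2)c(=O)n1Cc1ccccc1` differs from compound 2 as follows: methyl in place of cyclohexyl on a nitrogen on an aromatic ring. Going by the values given here, no measured step touches this position, so nothing in the data points to a change beyond the scatter in this assay. The number for compound 4 is therefore expected to sit close to that of compound 2, and the expected step is a 1.1-fold higher number from compound 2 to compound 4 (0.03 log units; within the scatter). The estimate for compound 4 in this assay is 80000 nM, with a range from 35000 nM to 200000 nM.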

Compound 4, half-maximal cytotoxic concentration: 65000 nM
Compound 4: the middle estimate sits 1.2-fold (0.09 log units) above what was measured, and the stated range covers the measured number.
By their numbers in this assay, from the lowest: compounds 3, 4 and 2 (each within the scatter of the next). At a limit, above all of these: compound 1.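

For the compounds shown here, this step gives the series its only reading at the amine: in this assay, methyl in place of cyclohexyl on a nitrogen on an aromatic ring gives a 1.1-fold lower number from compound 2 to compound 4 (0.06 log units; within the scatter). A six-membered non-aromatic ring of carbon only and a single methyl therefore cannot be told apart at this place, as far as compound 2 and compound 4 go, and this holds for this pair alone. Unlike the earlier step, which has a limit at one end, this one joins two numbers, and neither compound sits at the limit of the assay, which is reached only by compound 1: the limit of > 100000 nM in this assay, at which 1 of the 4 values shown sits.

Open, on these data alone, is whether an unsubstituted amino group, a longer alkyl chain or a chain ending in a carboxylic acid on this nitrogen would also stay within the scatter of compound 2 in this assay. Also open, as far as these compounds go, is whether cyclohexylamino to methylamino would read the same with a cyano or pyridin-2-yl group on the saturated chain carbon bound to an aromatic nitrogen, in place of the group shared by compound 2 and compound 4.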